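The source may hold more compounds than are shown below. What is called first, only, known or untested is meant among the compounds shown, and "the series" means these compounds.

Of the compounds shown here, three of this set have been measured in a functional assay on P388 cells (Mus musculus) for cytotoxicity, read by MTT assay, with a stated time of 72 h; a lower number here means a stronger inhibitor, a higher number a weaker inhibitor. Compound 1 `CCOc1ccc(NS(=O)(=O)c2ccc(OC)cc2)c2c(Cl)n[nH]c12` gives 580 nM. Compound 2 `C=CCn1ncc2c(NS(=O)(=O)c3ccc(C)cc3)ccc(OCC)c21` gives 51800 nM. Compound 3 `Cc1ccc(S(=O)(=O)Nc2ccc3c[nH]nc3c2)cc1` gives 71300 nM, the highest number of the three, within the scatter of compound 2 and far beyond the scatter from compound 1.

Compound 4 `C=CCn1cc2ccc(NS(=O)(=O)c3ccc(C)cc3)cc2n1` differs from compound 3 by one change: allyl in place of hydrogen on an aromatic nitrogen. Compound 2 carries an allyl group on a ring nitrogen of its core and is within the scatter of compound 3, so no step beyond the scatter is expected in this assay from compound 3 to compound 4, the expected step being a 1.2-fold lower number from compound 3 to compound 4 (0.07 log units; within the scatter). Compound 4 is therefore expected to give about 60000 nM, between 20000 nM and 180000 nM.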

Compound 4, half-maximal inhibitory concentration: 4410 nM
Beside the measured number, compound 4's estimate is 14-fold (1.13 log units) above it, and the stated range ends above it.
By their numbers in this assay, from the lowest: compound 1; then compound 4; then compounds 2 and 3 (each within the scatter of the next).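

Among these compounds, this is the first single change in the set, and in this assay allyl in place of hydrogen on an aromatic nitrogen gives a 16-fold lower number from compound 3 to compound 4 (1.21 log units; beyond the scatter) as a large step. At this position, then, the hydrogen on the ring nitrogen is not needed for the lower number, and a group of this size goes with a clear gain. Nothing available here explains the step.

The compounds shown leave open whether a methyl, a longer chain or an amine on this nitrogen would act as allyl does. They also leave open whether the same change carries over to the core of compound 1.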